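Opening a Ring on a Shared Core

The source may report more compounds than this note shows. Statements on the series, on what has been measured and on what is new or still open speak of the compounds shown alone.

Two compounds set the stage. Compound 1 `CN(C)c1nc(N2CCNCC2)nc2nc(NCc3ccccc3)c(Cl)nc12` and compound 2 `CN1CCN(c2nc(N3CCCC3)c3nc(Cl)c(NCc4ccccc4)nc3n2)CC1` share a fused core and were tested in a functional assay (Homo sapiens) for inhibition, read by sulforhodamine B assay, with a stated time of 3 days; on this read-out lower numbers stand for stronger inhibition and higher numbers for weaker inhibition. In this assay compound 1 gives 5900 nM, while compound 2 gives 6500 nM. Compound 2 has the higher of the two numbers, yet its gap to compound 1 lies within the usual scatter, so the two cannot be told apart.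

Compound 3 `NCCNc1nc(N2CCCC2)c2nc(Cl)c(NCc3ccccc3)nc2n1` has not yet been measured. It differs from compound 2 in one place: (2-aminoethyl)amino in place of 4-methylpiperazin-1-yl on an aromatic carbon. Among the compounds with values here, no step from one measured compound to another is known here, so nothing shows how large such a change tends to be. The step from compound 2 to compound 3 is expected to be a 1.3-fold lower number from compound 2 to compound 3 (0.11 log units; within the scatter), small and in no clear direction beyond the scatter. Compound 3 is therefore estimated at 5000 nM, with a range from 1500 nM to 15000 nM.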

Compound 3, half-maximal inhibitory concentration: 3200 nM
For compound 3 the middle estimate is 1.6-fold (0.19 log units) above the measured one, within the range that was stated.
By their numbers in this assay, from the lowest: compounds 3, 1 and 2 (each within the scatter of the next, the first and the last beyond it).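

In this assay, within the data shown here, the swap of 4-methylpiperazin-1-yl for (2-aminoethyl)amino gives a 2.0-fold lower number from compound 2 to compound 3 (0.31 log units; beyond the scatter) and so supplies the first measured step that stands clear of the scatter. It shows that, on this aromatic carbon between two ring nitrogen atoms, the six-membered non-aromatic ring can give way to an open chain with no loss on this read-out, and with a modest gain. Nothing measured here bears on why the number moves.

This one swap removes the ring and adds hydrogen-bond donors together, so the compounds shown cannot separate the two changes. Going by these compounds, whether a longer chain such as (3-aminopropyl)amino, or a hydroxyl group in place of the terminal amine, would move the number further stays open.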